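Cytotoxicity of two arylidene imides with amide-linked aryl groups

The compounds below may be only part of what the source reports. "The series", "measured", "known", "first", "only" and "open" are said of these compounds alone.

Compound 1, `Cc1ccc(N2C(=O)C/C(=C\c3cccc(C(=O)Nc4cccc(F)c4)c3)C2=O)cc1`, in an ADME assay on HCT-116 cells (Homo sapiens) for cytotoxicity, read by MTT assay, with a stated time of 72 h (on this read-out higher numbers stand for weaker inhibition and lower numbers for stronger inhibition), gives > 100000 nM.
Compound 2, `O=C(Nc1ccc(OC(F)F)cc1)c1cccc(/C=C2\CC(=O)N(c3ccccc3)C2=O)c1`, in this assay gives > 100000 nM.

Both values are limits of the assay rather than numbers. Compound 2 therefore stands at the limit of the assay, with no number of its own; compound 1 shows the same limit, and the two compounds cannot be ordered against each other, since the limit of > 100000 nM in this assay, at which 2 of the 2 values shown sit, is all that the data hold.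

Compound 3, `O=C(Nc1cccc(F)c1)c1cccc(/C=C2\CC(=O)N(c3ccccc3)C2=O)c1`, has not been measured in this assay. It differs from compound 2 in one place: 3-fluorophenyl in place of 4-(difluoromethoxy)phenyl on an amide-type nitrogen. The same 3-fluorophenyl group on the amide-type nitrogen is found in compound 1, where the read-out also sits at the limit. With no measured step between the two compounds shown, and both of them at the limit, no step beyond the scatter is expected in either direction. The step from compound 2 to compound 3 is estimated as a step that the limit leaves unreadable from compound 2 to compound 3. Compound 3 is expected to give 150000 nM, within 50000 nM to 500000 nM, most likely again reported only as a limit.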

Compound 3, half-maximal inhibitory concentration: > 100000 nM
Compound 3 ended at the assay's limit; the forecaster's own chance of this, stated with the estimate: 85%; the middle value lies beyond the limit too.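

In this assay compound 3 also ends at a limit and not at a number, so no step from compound 2 or from compound 1 to compound 3 can be read: the limit of > 100000 nM in this assay, at which 3 of the 3 values shown sit.

The compounds shown leave open how far past the limit each one lies, and whether 3-fluorophenyl, 4-(difluoromethoxy)phenyl or the methyl on the aromatic carbon makes any difference to the read-out.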